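A small aromatic swap in a cytotoxicity series

A few compounds are considered here, and "the series" means these few. Any claim that something is new, unique, unknown or untested is made for them only; others in the source may bear on it.

Measured so far:
Compound 1 `COc1ccc(C(c2ccc(OC)cc2)N2CCN(C(=O)COc3ccc4ccccc4c3)CC2)cc1` in a functional assay on PC-12 cells (Rattus norvegicus) for cytotoxicity, read by MTT assay, with a stated time of 24 h, tested at 1 uM (on this read-out higher numbers stand for a stronger effect at the one concentration tested and lower numbers for a weaker effect), gives 5.42%.
Compound 2 `O=C(COc1ccc2ccccc2c1)N1CCN(C(c2ccc(Br)cc2)c2ccc(Br)cc2)CC1` in this assay gives 7.87%.
Compound 3 `COc1ccc(C(c2ccc(OC)cc2)N2CCN(C(=O)COc3ccccc3C)CC2)cc1` in this assay gives 3.75%.

Compound 3 holds the lowest of the three numbers, yet its gaps to compound 1 and to compound 2 both fall within the scatter, so on these figures the three compounds cannot be told apart. For the measured compounds named here, the one step measured between neighbours, a number 1.7 percentage points lower from compound 1 to compound 3 (within the scatter), exchanges the group on the same oxygen on a saturated carbon that is changed again in the next step, and it moved nothing beyond the scatter.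

Compound 4 `COc1ccc(OCC(=O)N2CCN(C(c3ccc(OC)cc3)c3ccc(OC)cc3)CC2)cc1` differs from compound 3 in just that place: 4-methoxyphenyl in place of 2-methylphenyl on an oxygen on a saturated carbon. Going by the values given here, no other measured pair bears on this change; the step from compound 1 to compound 3 is the only precedent for altering this group, and it was flat. All three measured values sit in a narrow low band, so a number near that band is expected for compound 4, with the step of a number 1.3 percentage points higher from compound 3 to compound 4 (within the scatter) expected to stay within the scatter. Compound 4 is therefore estimated at 5% in this assay, within a range from 1% to 10%.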

Compound 4, a percentage reported as activity, at one concentration (the size of the read-out at that concentration, not a potency): 80.7%
For compound 4 the middle estimate is 75.7 percentage points below the measured one, outside the stated range (above it).
By their numbers in this assay, from the lowest: compounds 3, 1 and 2 (each within the scatter of the next); then compound 4.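

In this assay the group on an oxygen on a saturated carbon proves far from silent: the series moves by a number 77 percentage points higher from compound 3 to compound 4 (beyond the scatter) and likewise by a number 75.3 percentage points higher from compound 1 to compound 4 (beyond the scatter) once 4-methoxyphenyl enters, whereas the earlier exchange of naphthalen-2-yl for 2-methylphenyl gave only a number 1.7 percentage points lower from compound 1 to compound 3 (within the scatter) and so hid this sensitivity. Since the two groups that leave behave alike and the same entering group produces both large steps, the jump in these compounds goes with 4-methoxyphenyl itself on the shared core, and the only counted differences from 2-methylphenyl are its one oxygen and one hydrogen-bond acceptor. Nothing available explains why this single exchange has so large an effect.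

The compounds shown leave open whether the jump depends on the methoxy group or on where it sits, a question that 4-methylphenyl, 2-methoxyphenyl or 4-hydroxyphenyl in the same place could settle. They also leave open whether 4-methoxyphenyl gives the same high read-out on the core of compound 2, which carries bromine where compound 4 carries methoxy groups.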